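Removing the acetyl from the core amine: a paired comparison

The compounds below may be only part of what the source reports. "The series", "measured", "known", "first", "only" and "open" are said of these compounds alone.

Measured compounds:
- Compound 1, `COc1ncc(-c2ccc3nc(NC(C)=O)nn3c2)cc1NS(=O)(=O)c1ccc(C)cc1`: 1600 nM
- Compound 2, `COc1ncc(-c2ccc3nc(N)nn3c2)cc1NS(=O)(=O)c1ccc(C)cc1`: 2510 nM
- Compound 3, `COc1ncc(-c2ccn3nc(NC(C)=O)nc3c2)cc1NS(=O)(=O)c1ccc(F)cc1`: 2410 nM

These three compounds were tested in a functional assay on U-87MG ATCC cells (Homo sapiens) for antiproliferative activity, read by MTT assay, with a stated time of 48 h; on this read-out lower numbers stand for stronger inhibition and higher numbers for weaker inhibition. Compound 1 and compound 2 share one core and differ only in hydrogen in place of acetyl on a nitrogen on an aromatic ring; this change produced a 1.6-fold higher number from compound 1 to compound 2 (0.20 log units; within the scatter), so the two numbers cannot be told apart with confidence. Compound 3 carries a different core, and its sulfonyl aryl ring bears fluorine where compound 1 and compound 2 carry a methyl group; the difference between the two cores is not broken down here. In this assay compound 3 gives a number that sits close to the value of compound 2 and not far from that of compound 1, all three within the usual scatter of one another.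

Compound 4, `COc1ncc(-c2ccn3nc(N)nc3c2)cc1NS(=O)(=O)c1ccc(F)cc1`, has not yet been measured. It relates to compound 3 exactly as compound 2 relates to compound 1: hydrogen in place of acetyl on a nitrogen on an aromatic ring. The place of the change is described in the same words for both pairs, so this is the same change made on a different core.

Within the data shown here, the only guide to what this change does is the pair already measured, where compound 1 to compound 2 gave a 1.6-fold higher number from compound 1 to compound 2 (0.20 log units; within the scatter). On that basis the step is expected to be a 1.5-fold higher number from compound 3 to compound 4 (0.16 log units; within the scatter), a change of about the same size as before, sitting inside the scatter. Compound 4 is therefore estimated to give 3500 nM in this assay, with a likely range from 1800 nM to 7000 nM.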

Compound 4, half-maximal inhibitory concentration: 1770 nM
Estimate against measurement, compound 4: 2.0-fold (0.30 log units) above, and the stated range ends above it.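

In this assay, replacing the acetyl with hydrogen on the core of compound 3 gave a 1.4-fold lower number from compound 3 to compound 4 (0.13 log units; within the scatter), so on this core too the acetamido and amino forms cannot be told apart with confidence. Set beside the earlier pair, the two steps agree as closely as this read-out can show: the same change on two cores in this assay, a 1.6-fold higher number (0.20 log units; within the scatter) from compound 1 to compound 2 and a 1.4-fold lower number (0.13 log units; within the scatter) from compound 3 to compound 4, 2.1-fold (0.33 log units) apart, within the scatter of two such steps. This suggests that the change has no effect large enough to detect on either core, but it does not prove that the change has no effect or that the two cores respond identically, as small real effects could lie inside the scatter, and the two pairs differ not only in core but also in carrying methyl or fluorine on the sulfonyl aryl ring.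

The compounds shown leave open whether a group other than amino or acetamido at this place, such as a longer acyl chain or a carboxylic acid, would give a step beyond the scatter. They also leave open how the core alone matters, as no pair shown has different cores with the same sulfonyl aryl ring.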